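Ethoxycarbonyl for butyl on the shared core: a projection

The source may report more compounds than this note shows. Statements on the series, on what has been measured and on what is new or still open speak of the compounds shown alone.

Measured so far:
Compound 1 `CCCCc1cn(C(c2ccccc2)c2cc3cc(Br)ccc3nc2OC)nn1`: 5.46%
Compound 2 `COc1nc2ccc(Br)cc2cc1C(c1ccccc1)n1cc(-c2ccc(OC(F)(F)F)cc2)nn1`: 11.7%

In an ADME assay on PANC-1 cells (Homo sapiens) for cytotoxicity, read by sulforhodamine B assay, with a stated time of 48 h, tested at 10 uM (a lower number here means less inhibition, a higher number more inhibition at the concentration tested (going by the name of the read-out)), compound 1 gives 5.46%, the bottom of the two numbers shown, while compound 2 gives 11.7%; the only measured step, a number 6.2 percentage points higher from compound 1 to compound 2 (within the scatter), does not separate the two. Compound 3 `CCOC(=O)c1cn(C(c2ccccc2)c2cc3cc(Br)ccc3nc2OC)nn1` differs from compound 1 by ethoxycarbonyl in place of butyl on an aromatic carbon, the group sitting on an aromatic carbon of a five-membered aromatic ring with 3 nitrogen, so that 4-butyl-1H-1,2,3-triazol-1-yl becomes 4-(ethoxycarbonyl)-1H-1,2,3-triazol-1-yl. Among the measured compounds shown here, no measured pair carries this exact change; the single step that bears on it, from compound 1 to compound 2, swaps the same butyl for another group at the same place and stays within the scatter. On that basis no step beyond the scatter is expected, and the expected shift is a number 2.5 percentage points higher from compound 1 to compound 3 (within the scatter). Compound 3 is therefore estimated at 8%, with a range of -5% to 21%.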

Compound 3, a percentage reported as inhibition, at one concentration (the size of the read-out at that concentration, not a potency): 15.4%
Beside the measured number, compound 3's estimate is 7.4 percentage points below it; measured number inside the range.
By their numbers in this assay, from the lowest: compounds 1, 2 and 3 (each within the scatter of the next).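

On this aromatic carbon, three different groups can now be compared in this assay. Replacing butyl with ethoxycarbonyl gives a number 9.9 percentage points higher from compound 1 to compound 3 (within the scatter), and replacing 4-(trifluoromethoxy)phenyl with ethoxycarbonyl gives a number 3.7 percentage points higher from compound 2 to compound 3 (within the scatter), so neither step separates the compounds. Butyl has 0 hydrogen-bond acceptors and ethoxycarbonyl has 2, yet that difference in count comes with no step beyond the scatter, and no measurement at hand accounts for the numbers.

Going by these compounds, it remains open whether a carboxylic acid, a primary amine or a longer alkyl chain on this carbon would move the number beyond the scatter. The compounds shown also leave open whether this lack of separation would hold if the phenyl group on the shared core were exchanged.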